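The source may report more compounds than this note shows. Statements on the series, on what has been measured and on what is new or still open speak of the compounds shown alone.

Working notes on the series.

Compound 1 `COC(=O)[C@@]1(C)CCC=C2[C@@H]1CC[C@@H](C)[C@]2(C)Cc1c(C)[nH]c2c(Br)cccc12` and compound 2 `COC(=O)[C@@]1(C)CCC=C2[C@@H]1CC[C@@H](C)[C@]2(C)Cc1c(C)[nH]c2c(Cl)cccc12` share one core and differ only at the halogen on the indole. In a functional assay on HBL-100 cells (Homo sapiens) for inhibition, read by sulforhodamine B assay, with a stated time of 48 h (a lower number here means a stronger inhibitor of growth, a higher number a weaker inhibitor of growth), compound 1 gives 27000 nM, and compound 2 gives 22000 nM. The step of a 1.2-fold lower number from compound 1 to compound 2 (0.09 log units; within the scatter) comes from the change (chloro in place of bromo on an aromatic carbon).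

Compound 3 `COC(=O)[C@@]1(C)CC[C@@H]2C3=C1CC[C@@H](C)[C@]3(C)C[C@@H]1c3cc(Br)ccc3N[C@H]21` is built on a different core; the difference between the two cores is not broken down here. In this assay compound 3 gives 34000 nM, which stands within the scatter of both compound 1 and compound 2, so no order among the three can be read from these numbers.

Compound 4 `COC(=O)[C@@]1(C)CC[C@@H]2C3=C1CC[C@@H](C)[C@]3(C)C[C@@H]1c3cc(Cl)ccc3N[C@H]21` is still to be measured. It relates to compound 3 as compound 2 relates to compound 1, through the change (chloro in place of bromo on an aromatic carbon). Going by the values given here, this is the same kind of change as the one from compound 1 to compound 2, not the same change: here the aromatic carbon lies in a fused system of five rings, meta to a fused ring and para to a fused ring, whereas in the earlier pair it lies in a fused system of two rings, ortho to a fused ring and meta to a fused ring.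

Among the compounds with values here, the only guide is the single earlier step. Since that step, a 1.2-fold lower number from compound 1 to compound 2 (0.09 log units; within the scatter), lay within the scatter, the step from compound 3 to compound 4 in this assay is expected to be of similar size, a 1.1-fold lower number from compound 3 to compound 4 (0.05 log units; within the scatter). Compound 4 is therefore estimated at 30000 nM, with a likely range from 15000 nM to 60000 nM.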

Compound 4, concentration for 50% growth inhibition: 28000 nM
Compound 4: the middle estimate sits 1.1-fold (0.03 log units) above what was measured, within the range that was stated.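

In this assay the new pair gives a 1.2-fold lower number from compound 3 to compound 4 (0.08 log units; within the scatter), so chloro in place of bromo on an aromatic carbon stays within the scatter on this core as well. Set beside the earlier pair, the change reads the same on both cores: the same change on two cores in this assay, a 1.2-fold lower number (0.09 log units; within the scatter) from compound 1 to compound 2 and a 1.2-fold lower number (0.08 log units; within the scatter) from compound 3 to compound 4, 1.0-fold (0.00 log units) apart, within the scatter of two such steps. Going by these compounds alone, this shows that the change carried from one core to the other without a step beyond the scatter, even though the aromatic carbon sits in a different place in each; it does not show that the halogen is without bearing on growth inhibition more widely, since bromo and chloro are the only two groups compared, and two pairs say nothing about a third core.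

The compounds shown carry only bromo or chloro at the changing place, so it stays open whether fluoro, methoxy, a nitrile or plain hydrogen on that aromatic carbon would move the number beyond the scatter. As far as these compounds go, the methyl ester is common to all four compounds, so what a carboxylic acid or an amide in its place would do on either core also stays open.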